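A few compounds are considered here, and "the series" means these few. Any claim that something is new, unique, unknown or untested is made for them only; others in the source may bear on it.

Measured so far:
compound 1, `CCC(CC)c1ccc2c(NCCCNCc3ccco3)ccnc2c1`, 4200 nM
compound 2, `COc1ccccc1Oc1ccc2c(NCCCNCc3ccco3)ccnc2c1`, 14500 nM
compound 3, `COc1ccccc1Oc1ccc2c(NCCCNCc3cccc(OC)c3O)ccnc2c1`, 14500 nM

All three were tested in a physicochemical assay for solubility, with a stated time of 18 h, at pH 7.4; on this read-out lower numbers stand for lower solubility and higher numbers for higher solubility. Compound 2 and compound 3 share one core, and they differ only in one side group: 2-hydroxy-3-methoxyphenyl in place of furan-2-yl on a saturated chain carbon bound to an amine nitrogen. This change left the read-out unchanged, no change at the digits printed from compound 2 to compound 3 (within the scatter). Compound 1 differs from compound 2 by a change on the core itself, (pentan-3-yl in place of 2-methoxyphenoxy on an aromatic carbon), and here the number moved: a 3.5-fold lower number from compound 2 to compound 1 (0.54 log units; beyond the scatter).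

Compound 4, `CCC(CC)c1ccc2c(NCCCNCc3cccc(OC)c3O)ccnc2c1`, has not yet been measured in this assay. It differs from compound 3 by pentan-3-yl in place of 2-methoxyphenoxy on an aromatic carbon. This is the same change that turns compound 2 into compound 1, made on the same place, and it is seen twice among these compounds. Since the side group carried by compound 3 made no difference against compound 2 in this assay, the expectation is that compound 4 will repeat the step seen between compound 2 and compound 1, so the estimated step is a 3.4-fold lower number from compound 3 to compound 4 (0.53 log units; beyond the scatter). Compound 4 is therefore expected to give about 4300 nM, with a plausible range from 1500 nM to 12000 nM.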

Compound 4, solubility: 4200 nM
For compound 4 the middle estimate is 1.0-fold (0.01 log units) above the measured one, within the range that was stated.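

In this assay, the swap of 2-methoxyphenoxy for pentan-3-yl carried over from one core to the other: with the 2-hydroxy-3-methoxyphenyl side group it gave a 3.5-fold lower number from compound 3 to compound 4 (0.54 log units; beyond the scatter) and matched the furan-2-yl pair, a 3.5-fold lower number from compound 2 to compound 1 (0.54 log units; beyond the scatter) in size, while the side-group change that was silent on the first core stayed silent on the second, with no change at the digits printed from compound 1 to compound 4 (within the scatter) as the result. This shows that, for these four compounds, the two changes behave independently of each other, so each one's effect could be read without knowing the other, but two matching pairs in one assay do not make a general rule for the series. Nothing available explains the size of the step or the lack of one.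

With only two groups shown at each of the two places, it remains open whether the same step would appear with a carboxylic acid in place of 2-hydroxy-3-methoxyphenyl. A longer chain in place of pentan-3-yl, or an amine at that aromatic carbon, is equally untested by the compounds shown here.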